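This account rests on a few compounds, and the source may have more. Where it says the series, first, only, none or still open, it means among the compounds named here.

Working notes on the isatin-derived cinnamate series in a functional assay on K562 cells (Homo sapiens) for cytotoxicity, read by MTT assay, with a stated time of 48 h; on this read-out lower numbers stand for stronger inhibition and higher numbers for weaker inhibition.

Compound 1 `COC(=O)/C=C/c1ccc2c(c1)C(=O)C(=O)N2Cc1ccc(C)cc1` gives 40 nM in this assay. Compound 3 `COC(=O)/C=C/c1cccc2c1C(=O)C(=O)N2Cc1ccc(OC)cc1` gives 350 nM, and compound 2 `COC(=O)/C=C/c1cccc2c1N(Cc1ccc(OC)cc1)C(=O)C2=O` gives 4130 nM. Compound 1 therefore has the lowest number of the three; its gap to compound 3 is beyond the scatter, and its gap to compound 2 is wider still and also beyond the scatter. No pair among these three differs in only one place, so the two differences cannot be traced to a single change; the values are simply what they show.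

The next compound, compound 4 `COC(=O)/C=C/c1ccc2c(c1)C(=O)C(=O)N2Cc1ccccc1`, differs from compound 1 in one place: hydrogen in place of methyl on an aromatic carbon. The methyl is a single carbon on an aromatic carbon, para to a large group, and nothing else moves. Among the measured compounds shown here, no comparable step is available among the measured compounds. The expectation for the step from compound 1 to compound 4 is a 1.5-fold higher number from compound 1 to compound 4 (0.18 log units; within the scatter), small and within the scatter, if anything toward a slightly higher number. Compound 4 is expected to give 60 nM in this assay, with a range from 20 nM to 200 nM.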

Compound 4, half-maximal inhibitory concentration: 40 nM
Estimate against measurement, compound 4: 1.5-fold (0.18 log units) above; the measured number falls inside the stated range.
By their numbers in this assay, from the lowest: compounds 1 and 4 (each within the scatter of the next); then compound 3; then compound 2.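

In this assay, among the compounds shown here, hydrogen in place of methyl on an aromatic carbon, para to a large group, gives no change at the digits printed from compound 1 to compound 4 (within the scatter) in the first one-place comparison of the series. The low number of compound 1 therefore does not depend on this methyl, since compound 4 with its plain benzyl group gives 40 nM on the same core. Nothing available explains why this place tolerates the change.

Going by these compounds, it remains open whether the same place would accept a chlorine, a hydroxyl, a dimethylamino group or a longer chain such as butyl. Compounds 2 and 3 each differ from compound 4 in more than one place, so what lies behind their higher numbers also stays open.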